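This account rests on a few compounds, and the source may have more. Where it says the series, first, only, none or still open, it means among the compounds named here.

In a functional assay on RKO cells (Homo sapiens) for cytotoxicity, read by resazurin assay, with a stated time of 72 h (on this read-out lower numbers stand for stronger inhibition and higher numbers for weaker inhibition), three related compounds have been measured so far. Compound 1 `COc1ccc(Nc2nc(-n3ccnc3C)cs2)cc1` gives 1600 nM, the second highest of the three numbers. Compound 3 `Cc1ccc(Nc2nc(-n3ccnc3C)cs2)cc1` lies lower at 450 nM, while compound 2 `Cc1nccn1-c1csc(Nc2ccc(Br)cc2)n1` lies higher at 30000 nM.

Compound 4 `COc1ccc(Nc2nc(-n3cc(C)nc3C)cs2)cc1` has not yet been measured. It differs from compound 1 by methyl in place of hydrogen on an aromatic carbon, turning 2-methyl-1H-imidazol-1-yl into 2,4-dimethyl-1H-imidazol-1-yl (methyl in place of hydrogen on an aromatic carbon).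

Among the measured compounds shown here, no measured step changes that group. All three instead swap methoxy, bromo or methyl on a different aromatic carbon: the modest 3.6-fold lower number from compound 1 to compound 3 (0.55 log units; beyond the scatter), the large 19-fold higher number from compound 1 to compound 2 (1.27 log units; beyond the scatter) and the large 67-fold lower number from compound 2 to compound 3 (1.82 log units; beyond the scatter). These steps therefore give no direction for the new change. They bear on it only indirectly, showing that among these three compounds a swap of one small group always moved the number beyond the scatter. With no direct evidence, a small rise is a cautious guess, and a fall remains possible. The expected change is a 1.4-fold higher number from compound 1 to compound 4 (0.14 log units; within the scatter). For compound 4, the estimated value is 2200 nM, within an expected range of 500 nM to 9000 nM.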

Compound 4, half-maximal inhibitory concentration: 250 nM
Compound 4: the middle estimate sits 8.8-fold (0.94 log units) above what was measured, outside the stated range (below it).
By their numbers in this assay, from the lowest: compounds 4 and 3 (each within the scatter of the next); then compound 1; then compound 2.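

In this assay, among the compounds shown here, the swap of 2-methyl-1H-imidazol-1-yl for 2,4-dimethyl-1H-imidazol-1-yl brings a 6.4-fold lower number from compound 1 to compound 4 (0.81 log units; beyond the scatter) and is the first measured step to touch this group, showing that the number responds to changes here as well as to swaps on the other aromatic ring. The change is small: one carbon enters as a methyl, with no hydrogen-bond donor or acceptor and no net charge, yet a single hydrogen replaced on this aromatic carbon of the five-membered ring is enough to move the number beyond the scatter. Nothing measured here explains why this methyl goes with a lower number.

For the compounds shown here, with only one group tested at this carbon, it remains open whether an ethyl group, a chlorine atom, a hydroxymethyl group or an amine there would lower the number further, leave it alone or raise it. On these data alone, it is also open whether the same added methyl would have a similar effect on compound 3 or compound 2, which carry methyl and bromo in place of the methoxy of compound 1.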